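This account rests on a few compounds, and the source may have more. Where it says the series, first, only, none or still open, it means among the compounds named here.

Measured compounds and their values:

Compound 1, `CCn1c(C(=O)NCC(=O)OC)ccc1C(CC)(CC)c1ccc(OCS(=O)(=O)c2ccccc2)c(C)c1`: 20000 nM
Compound 2, `CCn1c(C(=O)NCCO)ccc1C(CC)(CC)c1ccc(OCS(=O)(=O)c2ccccc2)c(C)c1`: 19900 nM
Compound 3, `CCn1c(C(=O)NC(C)(C)CO)ccc1C(CC)(CC)c1ccc(OCS(=O)(=O)c2ccccc2)c(C)c1`: 18300 nM

All three were tested in a functional assay on BXPC-3 cells (Homo sapiens) for antiproliferative activity, read by MTT assay, with a stated time of 24 h; on this read-out higher numbers stand for weaker inhibition and lower numbers for stronger inhibition. Compound 1 gives 20000 nM in this assay, and the two other numbers sit within the usual scatter of it: the step of a 1.0-fold lower number from compound 1 to compound 2 (0.00 log units; within the scatter) and the step of a 1.1-fold lower number from compound 1 to compound 3 (0.04 log units; within the scatter) are both too small to count as real differences, so compound 1 cannot be set apart from compound 2 or compound 3 on these numbers.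

Compound 4, `CCn1c(C(=O)NCCCO)ccc1C(CC)(CC)c1ccc(OCS(=O)(=O)c2ccccc2)c(C)c1`, has not yet been measured in this assay. It differs from compound 1 by a single change: 2-hydroxyethyl in place of methoxycarbonyl on a saturated chain carbon bound to an amide-type nitrogen. The measured steps that bear on this are those in which the methoxycarbonyl group was likewise exchanged for a hydroxyl-bearing chain, a 1.0-fold lower number from compound 1 to compound 2 (0.00 log units; within the scatter) and a 1.1-fold lower number from compound 1 to compound 3 (0.04 log units; within the scatter), both within the scatter. Since the lengthening by one carbon is the only further difference, no step beyond the scatter is expected in either direction.

Compound 4 is therefore estimated to give 20000 nM in this assay, with a range from 10000 nM to 40000 nM, which means an expected step of no change at the digits printed from compound 1 to compound 4 (within the scatter).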

Compound 4, half-maximal inhibitory concentration: 26600 nM
Compound 4: middle estimate off by 1.3-fold (0.12 log units), on the low side, and the stated range covers the measured number.
By their numbers in this assay, from the lowest: compounds 3, 2, 1 and 4 (each within the scatter of the next).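

In this assay the 3-hydroxypropyl chain on the amide nitrogen of compound 4 stays within the scatter of all three earlier compounds, whether set against the 2-hydroxyethyl chain (a 1.3-fold higher number from compound 2 to compound 4 (0.13 log units; within the scatter)), the (methoxycarbonyl)methyl chain (a 1.3-fold higher number from compound 1 to compound 4 (0.12 log units; within the scatter)) or the branched 1-(hydroxymethyl)-1-methylethyl chain (a 1.5-fold higher number from compound 3 to compound 4 (0.16 log units; within the scatter)). This position has now carried a straight hydroxyl-bearing chain of two lengths as well as a branched one and an ester, and none of these swaps gives a step beyond the scatter, so the four compounds cannot be ranked on these numbers. No measurement in hand offers a reason for this flat result.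

Still open, going by these compounds, is whether a group of another kind at this chain end, such as an amine or a carboxylic acid, or a much longer chain, would give a step beyond the scatter. On these data alone, all four compounds also share the same core, so it remains unknown whether the same swaps would stay as flat on a different core.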